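This account rests on a few compounds, and the source may have more. Where it says the series, first, only, none or still open, it means among the compounds named here.

Compound 1 `CC(C)(C)OC(=O)N1CC=C(c2cn(-c3ccc(F)cc3)nn2)CC1` and compound 2 `Cc1ccccc1-n1cc(C2=CCN(C(=O)OC(C)(C)C)CC2)nn1` share the same core and differ only in the group on the aromatic nitrogen. In a functional assay on CHO cells for antagonist activity at metabotropic glutamate receptor 5 (Homo sapiens), read by FLIPR and calcium flux (a higher number here means a weaker inhibitor, a lower number a stronger inhibitor), compound 1 gives 1100 nM, and in this assay compound 2 gives 880 nM. The change between them, a 1.3-fold lower number from compound 1 to compound 2 (0.10 log units; within the scatter), leaves the two values within the scatter of each other. For the measured compounds named here, compound 2 therefore stands at the lower of the two numbers so far, with compound 1 as its nearest neighbour, the gap not separable from repeat variation.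

Compound 3 `CC(C)(C)OC(=O)N1CC=C(c2cn(-c3ccccn3)nn2)CC1` is the next member: pyridin-2-yl in place of 2-methylphenyl on an aromatic nitrogen. Going by the values given here, the only measured step that bears on this position is the one from compound 1 to compound 2, and it was within the scatter. Among the compounds with values here, no measured step covers a nitrogen-containing ring at this position, so the expectation rests on that single step alone. For compound 3 the step in this assay is expected to be a 1.3-fold higher number from compound 2 to compound 3 (0.10 log units; within the scatter), that is, not beyond the scatter. Compound 3 is accordingly estimated at 1100 nM, with a range of 400 nM to 3000 nM.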

Compound 3, half-maximal inhibitory concentration: 8700 nM
For compound 3 the middle estimate is 7.9-fold (0.90 log units) below the measured one, and the stated range ends below it.
By their numbers in this assay, from the lowest: compounds 2 and 1 (each within the scatter of the next); then compound 3.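

For the compounds shown here, at the aromatic nitrogen of the five-membered ring, pyridin-2-yl gives the first change beyond the scatter in this assay: a 9.9-fold higher number from compound 2 to compound 3 (1.00 log units; beyond the scatter), and a 7.9-fold higher number from compound 1 to compound 3 (0.90 log units; beyond the scatter). This position therefore does respond to the choice of aromatic ring, although 2-methylphenyl and 4-fluorophenyl could not be separated there. The change also removes the ring substituent while adding a ring nitrogen and a hydrogen-bond acceptor, and no measurement on hand accounts for the loss.

The compounds shown leave open whether the ring nitrogen or the absence of a substituent matters, a question that unsubstituted phenyl would address. Pyridin-3-yl and pyridin-4-yl would show whether the place of the ring nitrogen matters, and a methyl group on the pyridin-2-yl ring would show whether a substituent recovers the lower number.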